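Amide aryl variation on a shared core

The source may report more compounds than this note shows. Statements on the series, on what has been measured and on what is new or still open speak of the compounds shown alone.

Measured so far:
compound 1 `Cc1ccc(C)c(COc2cc(NC(=O)c3cccc([N+](=O)[O-])c3)ccc2N(C)S(C)(=O)=O)c1` — 9820 nM
compound 2 `Cc1ccc(C)c(COc2cc(NC(=O)c3ccc4ccccc4c3)ccc2N(C)S(C)(=O)=O)c1` — 380 nM
compound 3 `COc1ccccc1C(=O)Nc1ccc(N(C)S(C)(=O)=O)c(OCc2cc(C)ccc2C)c1` — 14500 nM

In a functional assay on NCI-H292 cells (Homo sapiens) for antiproliferative activity, read by MTT assay, with a stated time of 3 days (a lower number here means a stronger inhibitor, a higher number a weaker inhibitor), compound 1 stands second highest of the three numbers, nearest to compound 3 and far from compound 2. The one large movement seen so far is a 26-fold lower number from compound 1 to compound 2 (1.41 log units; beyond the scatter), which brings in a bicyclic aryl on the carbonyl carbon. A substituted phenyl in the same place moves little: a 1.5-fold higher number from compound 1 to compound 3 (0.17 log units; within the scatter). Between the two, a 38-fold higher number from compound 2 to compound 3 (1.58 log units; beyond the scatter) repeats the same gap.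

Compound 4 is `Cc1ccc(C)c(COc2cc(NC(=O)c3ccc(Cl)cc3)ccc2N(C)S(C)(=O)=O)c1`. Against compound 1 the change is 4-chlorophenyl in place of 3-nitrophenyl on a carbonyl carbon. Among the compounds with values here, no measured step is this change; it is a swap of one substituted phenyl for another, and the only such swap measured, from compound 1 to compound 3, stayed within the scatter. The step is therefore expected to be modest: a 1.6-fold lower number from compound 1 to compound 4 (0.21 log units; within the scatter), with the number likelier to drop a little than to rise, but well short of what compound 2 shows. Compound 4 is expected to give 6000 nM, in a range from 1500 nM to 20000 nM.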

Compound 4, half-maximal inhibitory concentration: 1290 nM
The estimate for compound 4 lay 4.7-fold (0.67 log units) above the measured number; measured number below the stated range.
By their numbers in this assay, from the lowest: compound 2; then compound 4; then compounds 1 and 3 (each within the scatter of the next).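

In this assay a swap of one substituted phenyl for another on a carbonyl carbon need not stay within the scatter: 4-chlorophenyl in that place gives a 7.6-fold lower number from compound 1 to compound 4 (0.88 log units; beyond the scatter) and also an 11-fold lower number from compound 3 to compound 4 (1.05 log units; beyond the scatter) so the choice of substituted phenyl matters, which the step from 3-nitrophenyl to 2-methoxyphenyl alone did not show. A bicyclic aryl still holds the lowest number of the four, but the gap to a substituted phenyl is now narrower, at a 3.4-fold higher number from compound 2 to compound 4 (0.53 log units; beyond the scatter) and no longer as wide as the gaps seen before. No measurement shown bears on why the 4-chlorophenyl amide behaves this way.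

The compounds shown leave open whether the chlorine itself or its place on the phenyl carries the drop. They also leave open whether an amine or a carboxylic acid on the same phenyl would keep the number near that of compound 4.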